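Working notes: nitro in place of hydrogen on compound 3

A few compounds are considered here, and "the series" means these few. Any claim that something is new, unique, unknown or untested is made for them only; others in the source may bear on it.

Measured in a functional assay on HCT-116 cells (Homo sapiens) for antiproliferative activity, read by MTT assay, with a stated time of 48 h; on this read-out higher numbers stand for weaker inhibition and lower numbers for stronger inhibition
compound 1 `COc1ccc(N(C)c2ccnc(Cl)n2)cc1Cl` gives 1170 nM
compound 2 `COc1ccc(N(C)c2ccnc(Cl)n2)cc1OCC[Se]C#N` gives 1220 nM
compound 3 `COc1ccc(N(C)c2cc(C)nc(C)n2)cc1` gives 1320 nM

The three values lie within the scatter of one another, so compound 3 stands level with compounds 1 and 2 on these numbers.

Compound 4 `COc1ccc(N(C)c2cc(C)nc(C)n2)cc1[N+](=O)[O-]` follows from compound 3 by nitro in place of hydrogen on an aromatic carbon with nitro in place of hydrogen on an aromatic carbon, ortho to a methoxy group. Going by the values given here, no compound with a nitro group has been measured yet. Among the compounds with values here, the one measured step at that carbon is a 1.0-fold higher number from compound 1 to compound 2 (0.02 log units; within the scatter) and it stays within the scatter, although compounds 1 and 2 also differ from compound 3 elsewhere in the core. Because of a 1.0-fold higher number from compound 1 to compound 2 (0.02 log units; within the scatter) no step beyond the scatter, in either direction, is expected in this assay for this change. A single step is thin support, so the expected range is kept wide. The estimated step is a 1.1-fold lower number from compound 3 to compound 4 (0.04 log units; within the scatter) and it amounts to little change. For compound 4 the expected value is 1200 nM with an estimated range from 400 nM to 3500 nM as the likely span of repeat measurements.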

Compound 4, half-maximal inhibitory concentration: 4670 nM
The estimate for compound 4 lay 3.9-fold (0.59 log units) below the measured number, outside the stated range (above it).
By their numbers in this assay, from the lowest: compounds 1, 2 and 3 (each within the scatter of the next); then compound 4.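

In this assay, nitro in place of hydrogen on an aromatic carbon, ortho to a methoxy group, gives a 3.5-fold higher number from compound 3 to compound 4 (0.55 log units; beyond the scatter), the only step shown that lies beyond the scatter, and it runs towards weaker inhibition. This carbon is therefore not indifferent to what it carries, which the other step involving this carbon, a 1.0-fold higher number from compound 1 to compound 2 (0.02 log units; within the scatter), did not reveal; that step exchanges chlorine for a selenium-bearing chain on a different core, so it says nothing direct about nitro or about the core of compound 3. No measurement at hand bears on the origin of the loss, and the step stands here as an observation only.

Still open, going by these compounds, is whether the weaker inhibition belongs to nitro itself or would follow from any substituent at this carbon on the core of compound 3, a question that an amine, a chlorine or a carboxylic acid at the same place would help to settle. Equally open, on these data alone, is whether nitro at this carbon would give a step of similar size on the core of compound 1.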